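This account rests on a few compounds, and the source may have more. Where it says the series, first, only, none or still open, it means among the compounds named here.

Measured in a functional assay on HCT-116 cells (Homo sapiens) for inhibition, read by CCK-8 assay, with a stated time of 72 h, tested at 2 uM; a higher number here means more inhibition of growth at the concentration tested, a lower number less inhibition of growth:

- Compound 1 `Cc1cc(C)cc(SCc2ccc(/C=C/C(=O)Nc3ccccc3N)cc2)c1`: 7.98%
- Compound 2 `Nc1ccccc1NC(=O)c1ccc(CSc2cccc(F)c2)cc1`: 5.5%

Only these two compounds have been measured so far, and both numbers are small. Compound 2 gives 5.5% and compound 1 gives 7.98%. These values lie within the usual scatter of each other, so they cannot be ranked.

Compound 3 `Nc1ccccc1NC(=O)c1ccc(CSCCc2ccccc2)cc1` keeps the rest of compound 2 but carries phenethyl in place of 3-fluorophenyl on a sulfur. Both the leaving and the entering group hold one six-membered aromatic ring of carbon only.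

Among the compounds with values here, no two measured compounds differ in just one place, so there is no direct precedent for the size of this step. The best guide is the low level seen so far, with compound 2 at 5.5%. In this assay, no change beyond the scatter is therefore expected, in either direction. The expected step is a number 2.5 percentage points higher from compound 2 to compound 3 (within the scatter). For compound 3 the estimated value is 8%, with an expected range of 0% to 22%.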

Compound 3, percent growth inhibition at one concentration: 30.5%
The estimate for compound 3 lay 22.5 percentage points below the measured number, outside the stated range (above it).
By their numbers in this assay, from the lowest: compounds 2 and 1 (each within the scatter of the next); then compound 3.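

In this assay, within the data shown here, putting phenethyl in place of 3-fluorophenyl on a sulfur gives a number 25 percentage points higher from compound 2 to compound 3 (beyond the scatter), the first sign that the group at this position can move the read-out beyond the scatter. The change is a subtle one on paper: both groups hold one six-membered aromatic ring of carbon only, neither has hydrogen-bond donors or acceptors, and neither carries a net charge, so the difference that can be counted is 7 against 8 heavy atoms, with the fluorine gone and a carbon chain present in phenethyl. No measurement shown here explains why the number rises.

This single step removes the fluorine and brings in the chain together, so the compounds shown cannot say which of the two matters, or whether both do. An unsubstituted phenyl or a benzyl on the sulfur would help separate the two, while a longer chain such as 3-phenylpropyl, or an amine in place of the ring, would show how far the rise in this assay extends.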